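This account rests on a few compounds, and the source may have more. Where it says the series, first, only, none or still open, it means among the compounds named here.

Measured compounds:
compound 1 `COc1cc(-c2nnc(SCC(=O)c3ccc(C)cc3)n2N)cc(OC)c1OC`, in an ADME assay on HEK293 cells (Homo sapiens) for cytotoxicity, read by MTT assay, with a stated time of 48 h (a higher number here means a weaker inhibitor, a lower number a stronger inhibitor), compound 1 gives 100000 nM.
compound 3 `COc1cccc(NC(=O)CSc2nnc(-c3cc(OC)c(OC)c(OC)c3)n2N)c1`, in this assay compound 3 gives 100000 nM.
compound 2 `COc1cc(-c2nnc(SCC(=O)c3ccc(C(F)(F)F)cc3)n2N)cc(OC)c1OC`, in this assay compound 2 gives "not determined" (no result reported), so no result is reported for it.

Compound 2 thus stands nowhere on the numbers; only its structure is known. Compound 4 `COc1cc(-c2nnc(SCC(=O)Nc3ccccc3F)n2N)cc(OC)c1OC` differs from it by (2-fluorophenyl)amino in place of 4-(trifluoromethyl)phenyl on a carbonyl carbon. For the measured compounds named here, the one measured step on the same carbonyl carbon runs from an aryl group to an arylamino group, as here: no change at the digits printed from compound 1 to compound 3 (within the scatter). That step left the read-out where it was, so no shift beyond the scatter is expected for the same kind of exchange in compound 4. Compound 4 is therefore expected to give about 100000 nM in this assay, within 50000 nM to 200000 nM.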

Compound 4, half-maximal inhibitory concentration: > 100000 nM
Compound 4 gave a limit, no number; the forecaster's own chance of this, stated with the estimate: 40%; the middle value sits exactly at the limit.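

In this assay compound 4 gives > 100000 nM, a limit of the assay and not a number. Placing 2-fluorophenyl on the amide-type nitrogen gives a number no lower from compound 3 to compound 4 (the limit leaves the size open), and the exchange on the carbonyl carbon gives a number no lower from compound 1 to compound 4 (the limit leaves the size open). A fluorinated arylamino group on this carbonyl carbon therefore brings no lower number, and the series reaches the end of the readable range: the limit of > 100000 nM in this assay, at which 1 of the 4 values shown sits.

As far as these compounds go, whether any group at this place can lower the number remains open, and compound 2 gives no reading for 4-(trifluoromethyl)phenyl. A saturated amine or a carboxylic acid on the carbonyl carbon would test this beyond the aryl and arylamino groups shown.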